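Swapping fluorines for chlorines on a weakly binding benzoxazole amide

A few compounds are considered here, and "the series" means these few. Any claim that something is new, unique, unknown or untested is made for them only; others in the source may bear on it.

Compound 2 `C[C@H](Oc1cccc(F)c1F)C(=O)Nc1ccc2oc(-c3ccc(F)cc3)nc2c1` is one of three close relatives tested in an assay on isolated protein for inhibition of GMP reductase 2 (Homo sapiens), read by spectrophotometry; on this read-out higher numbers stand for weaker inhibition and lower numbers for stronger inhibition. In this assay compound 2 reaches only the limit > 5000 nM, which is a limit of the measurement and not a number. Compound 1 `COc1ccc(-c2nc3cc(NC(=O)[C@H](C)Oc4cccc(F)c4F)ccc3o2)cc1` likewise shows only the limit > 5000 nM. Compound 3 `C[C@H](Oc1cccc(F)c1F)C(=O)Nc1ccc2oc(-c3ccncc3)nc2c1` also sits at the limit > 5000 nM. The shifts between them are therefore unreadable: a step that the two limits leave unreadable from compound 1 to compound 2, a step that the two limits leave unreadable from compound 1 to compound 3, and a step that the two limits leave unreadable from compound 2 to compound 3, since (the limit of > 5000 nM in this assay, at which 3 of the 3 values shown sit). Compound 4 `C[C@H](Oc1cccc(Cl)c1Cl)C(=O)Nc1ccc2oc(-c3ccc(F)cc3)nc2c1` differs from compound 2 by 2,3-dichlorophenyl in place of 2,3-difluorophenyl on an oxygen on a saturated carbon. For the measured compounds named here, no measured step speaks to this change, and every value here is a limit, so a weak binder is expected again; the expected step is a step that the limit leaves unreadable from compound 2 to compound 4, and compound 4 is estimated at 8000 nM, within 1500 nM to 40000 nM.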

Compound 4, inhibition constant: > 5000 nM
Compound 4: a limit, no number (the forecaster's own chance of this, stated with the estimate: 70%); the middle value is on the limit's open side.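

In this assay, for the compounds shown here, compound 2 and compound 4 both give only a limit, so no step between them can be read. On these data alone, how 2,3-dichlorophenyl and 2,3-difluorophenyl compare in strength of inhibition stays open.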